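A few compounds are considered here, and "the series" means these few. Any claim that something is new, unique, unknown or untested is made for them only; others in the source may bear on it.

Compound 1, `CN1CC[C@@H](c2ccc(Cl)cc2)[C@H](C(=O)NCc2ccc(CNC(=O)[C@@H]3CN(C)CC[C@H]3c3ccc(Cl)cc3)cc2)C1`, gives 2270 nM in an assay on a subcellular fraction from brain for inhibition of sodium-dependent dopamine transporter (Rattus norvegicus); on this read-out lower numbers stand for stronger inhibition and higher numbers for weaker inhibition.
Compound 2, `CN1CC[C@@H](c2ccc(Cl)cc2)[C@H](C(=O)NCc2ccc(CNC(=O)c3ccc(Cl)cc3)cc2)C1`, gives 3710 nM in this assay.

Among these two measured compounds, compound 2 has the higher number in this assay, but its gap to compound 1 lies within the scatter of repeated measurements, so the two cannot be told apart on these data. The next compound, compound 3, `CN1CC[C@@H](c2ccc(Cl)cc2)[C@H](C(=O)NCc2ccc(CNC(=O)CCc3ccccc3)cc2)C1`, has not yet been measured. It differs from compound 2 in one place: phenethyl in place of 4-chlorophenyl on a carbonyl carbon. Among the measured compounds shown here, no measured pair shows what such a change does here, so there is no reference step to lean on. The expectation is therefore that the step from compound 2 to compound 3 stays within the scatter, and it is estimated as a 1.1-fold lower number from compound 2 to compound 3 (0.03 log units; within the scatter) in this assay. On that basis compound 3 is expected to give roughly 3500 nM in this assay, with a range from 1200 nM to 10000 nM.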

Compound 3, inhibition constant: > 2000 nM
Compound 3: no number, only a limit (the forecaster's own chance of this, stated with the estimate: 10%); the middle value is on the limit's open side.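

Compound 3 gives only a limit, not a number, so no step from compound 2 to compound 3 can be read: the limit of > 2000 nM in this assay, at which 1 of the 3 values shown sits.

The compounds shown leave open whether phenethyl in place of 4-chlorophenyl on a carbonyl carbon shifts the number in this assay at all, and in which direction.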